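Halogen-to-trifluoromethyl exchange on the fused ring

The source may hold more compounds than are shown below. What is called first, only, known or untested is meant among the compounds shown, and "the series" means these compounds.

Measured so far:
compound 1, `Cc1ccc2[nH]c(-n3[nH]c(C)c(Cc4ccccc4)c3=O)nc2c1`, 670 nM in an assay on isolated protein for inhibition of alpha-ketoglutarate-dependent dioxygenase alkB homolog 3 (Homo sapiens), read by polymerase chain reaction, with a stated time of 1 h; a higher number here means a weaker inhibitor, a lower number a stronger inhibitor
compound 2, `Cc1[nH]n(-c2nc3cc(Br)ccc3[nH]2)c(=O)c1Cc1ccccc1`, 490 nM in this assay

The two numbers lie within the scatter of one another; compound 2 stands beside compound 1, not apart from it. Compound 3, `Cc1[nH]n(-c2nc3cc(C(F)(F)F)ccc3[nH]2)c(=O)c1Cc1ccccc1`, differs from compound 2 by trifluoromethyl in place of bromo on an aromatic carbon. Among the measured compounds shown here, the only step bearing on this position is a 1.4-fold lower number from compound 1 to compound 2 (0.14 log units; within the scatter), which stayed within the scatter. For the measured compounds named here, no step of the kind bromo to trifluoromethyl has been measured here. Compound 3 is therefore expected to give 500 nM, within 200 nM to 1300 nM. The expected step is a 1.0-fold higher number from compound 2 to compound 3 (0.01 log units; within the scatter), none beyond the scatter.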

Compound 3, half-maximal inhibitory concentration: 610 nM
Beside the measured number, compound 3's estimate is 1.2-fold (0.09 log units) below it; low and high end bracket the measured number.
By their numbers in this assay, from the lowest: compounds 2, 3 and 1 (each within the scatter of the next).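

In this assay, trifluoromethyl on this aromatic carbon reads the same as bromo (a 1.2-fold higher number from compound 2 to compound 3 (0.10 log units; within the scatter)) and as methyl (a 1.1-fold lower number from compound 1 to compound 3 (0.04 log units; within the scatter)). All three groups now lie within the scatter of one another, so this position has yet to show any step beyond it among compounds 1, 2 and 3. Nothing available accounts for this flat reading. On these data alone, whether an amine or a carboxylic acid on this carbon would leave the scatter remains open. So does whether the same flat reading would hold with a plain hydrogen there.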